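A few compounds are considered here, and "the series" means these few. Any claim that something is new, unique, unknown or untested is made for them only; others in the source may bear on it.

Measured so far:
compound 1 `CC1(C)COC(c2cccc(OC(=O)NC3CCCCC3)c2)=N1` – 20%
compound 2 `C[C@H]1COC(c2cccc(OC(=O)NC3CCCC3)c2)=N1` – 28%

In an assay on membranes from cerebellum (strain Wistar) for inhibition of Monoglyceride lipase (Rattus norvegicus), read by HPLC, tested at 100 uM (on this read-out lower numbers stand for less inhibition and higher numbers for more inhibition at the one concentration tested (going by the name of the read-out)), compound 2 gives 28%, the higher of the two numbers shown. In this assay compound 1 gives 20%, and the gap to compound 2 lies within the usual scatter, so nothing separates the two.

Compound 3 `C[C@H]1COC(c2cccc(OC(=O)NC3CCCCC3)c2)=N1` differs from compound 2 by cyclohexyl in place of cyclopentyl on an amide-type nitrogen. Among the compounds with values here, no measured pair differs in one place only, so no step can be read from the numbers; compound 1 and compound 2 differ in more than one place and give values within the scatter of each other. Since compound 1, which carries the cyclohexyl, gives 20%, the change is expected to bring no step beyond the scatter in this assay. For compound 3 the expected value in this assay is 24%, in the range 10% to 40%. The expected step of a number 4 percentage points lower from compound 2 to compound 3 (within the scatter) is small and in no clear direction.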

Compound 3, a percentage reported as inhibition, at one concentration (the size of the read-out at that concentration, not a potency): 28%
The estimate for compound 3 lay 4 percentage points below the measured number; the measured number falls inside the stated range.
By their numbers in this assay, from the lowest: compounds 1, 2 and 3 (each within the scatter of the next).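

In this assay, within the data shown here, cyclohexyl in place of cyclopentyl on an amide-type nitrogen gives no change at the digits printed from compound 2 to compound 3 (within the scatter) and is the first reading of this position on its own: ring size here shows no effect on the number. The smaller group of 6 heavy atoms in place of the group of 7 on the aromatic carbon gives a number 8 percentage points higher from compound 1 to compound 3 (within the scatter) and so separates nothing either. No evidence beyond these readings bears on the result.

Still open, as far as these compounds go, is whether a phenyl ring or a straight hexyl chain on that nitrogen would move the number beyond the scatter.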